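Two Ring Stereocentres Inverted in Compound 1

The source may hold more compounds than are shown below. What is called first, only, known or untested is meant among the compounds shown, and "the series" means these compounds.

Compound 1 `C=C1CCCC(C)(C)C1CC[C@]1(C)CC[C@@H]([C@@H](C)C(=O)O)OO1` was tested in a functional assay on SN12C cells (Homo sapiens) for inhibition; on this read-out higher numbers stand for weaker inhibition of growth and lower numbers for stronger inhibition of growth. In this assay compound 1 gives only the limit > 10000 nM, which is a limit of the assay and not a number (the limit of > 10000 nM in this assay, at which 1 of the 2 values shown sits). Compound 2 `C=C1CCC[C@H]2[C@](C)(CC[C@]3(C)CC[C@@H]([C@@H](C)C(=O)O)OO3)[C@@H](C)CC[C@]12C` gives 780 nM in this assay, a number rather than a limit.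

Compound 3 `C=C1CCCC(C)(C)C1CC[C@@]1(C)CC[C@H]([C@@H](C)C(=O)O)OO1` has not been measured. Its difference from compound 1 is this: the two compounds have the same atoms and bonds; at least one stereo element is drawn with a configuration in one of them and without one in the other: 2 of 4 stereo elements differ; a stereocentre at a saturated ring carbon is drawn R in compound 1 and S in compound 3; a stereocentre at a saturated ring carbon is drawn S in compound 1 and R in compound 3. For the measured compounds named here, no measured step covers such a change, so no shift beyond the usual scatter is expected in this assay, in either direction. Compound 3 is therefore expected to give about 15000 nM, within 3000 nM to 60000 nM. The expected step is a step that the limit leaves unreadable from compound 1 to compound 3.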

Compound 3, concentration for 50% growth inhibition: 11300 nM
Beside the measured number, compound 3's estimate is 1.3-fold (0.12 log units) above it; the measured number falls inside the stated range.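

No step can be read between compound 1 and compound 3 in this assay, since the value of compound 1 is a limit and not a number: the limit of > 10000 nM in this assay, at which 1 of the 3 values shown sits. As far as these compounds go, what changing these two ring stereocentres does to growth inhibition stays open.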